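Fluorine removed and chain lengthened on an EP2 agonist

The source may hold more compounds than are shown below. What is called first, only, known or untested is meant among the compounds shown, and "the series" means these compounds.

Compound 1, `O=C(O)c1csc([C@H]2CC[C@@H]3[C@@H](COc4ccc(C(F)(F)F)cc4)[C@H](O)C[C@@H]3O2)n1`, in an assay on HEK293 cells for agonist activity at prostaglandin E2 receptor EP2 subtype (Homo sapiens), read by a beta-galactosidase reporter and beta-arrestin recruitment, with a stated time of 90 min; on this read-out lower numbers stand for an effect already at smaller amounts and higher numbers for an effect only at larger amounts of compound: > 10000 nM
Compound 2, `O=C(O)c1csc([C@H]2CC[C@@H]3[C@@H](COc4ccc(F)cc4)[C@H](O)C[C@@H]3O2)n1`, in this assay: > 10000 nM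

Both recorded values are limits of the assay, not numbers. Compound 2 stands at the limit of > 10000 nM in this assay, at which 2 of the 2 values shown sit. Among the compounds with values here, the only measured step, a step that the two limits leave unreadable from compound 1 to compound 2, is therefore unreadable: both of its ends are limits, so neither its size nor its direction can be told. The change to compound 3, `O=C(O)c1csc([C@H]2CC[C@@H]3[C@@H](CCOc4ccccc4)[C@H](O)C[C@@H]3O2)n1`, is phenoxymethyl in place of 4-fluorophenoxy on a saturated chain carbon bound to a saturated ring carbon. No readable step covers a change of this kind, and the two values in hand give no direction to lean on. The step that the limit leaves unreadable from compound 2 to compound 3 is the expected change, with no measured evidence pointing it either way. Compound 3 in this assay is estimated at 15000 nM, within an expected range from 3000 nM to 60000 nM, and it is likely to be reported again only as a limit.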

Compound 3, half-maximal effective concentration: > 10000 nM
Compound 3: only a limit was reported; the forecaster's own chance of this, stated with the estimate: 80%; the middle value is on the limit's open side.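

In this assay compound 3 gives > 10000 nM, which is a limit and not a number. No new step can be read from compound 2 to compound 3. The compounds shown leave open whether either (4-fluorophenoxy)methyl or 2-phenoxyethyl gives a measurable value in this assay.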